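The source may report more compounds than this note shows. Statements on the series, on what has been measured and on what is new or still open speak of the compounds shown alone.

Compound 1, `CC(C)(C)c1ccc(/C(=C/C(=O)Nc2ccc3c(c2)OCCO3)c2ccncc2)cc1`: 660 nM in a functional assay on CHO cells for inhibition of transient receptor potential cation channel subfamily V member 1 (Homo sapiens); on this read-out higher numbers stand for weaker inhibition and lower numbers for stronger inhibition.
Compound 2, `CC(C)(C)c1ccc(/C=C/C(=O)Nc2ccc3c(c2)NC(=O)CO3)cc1`: > 4000 nM, which is a limit of this assay and not a number.
Compound 3, `CCCCc1ccc(/C=C/C(=O)Nc2ccc3c(c2)OCCO3)cc1`: 2700 nM.

Of the two numbers, compound 3 gives the higher one, and the gap to compound 1 lies beyond the scatter. Compound 4, `O=C(/C=C/c1ccc(O)cc1)Nc1ccc2c(c1)OCCO2`, has not yet been measured in this assay. It differs from compound 3 by one change: hydroxy in place of butyl on an aromatic carbon. No step between measured compounds is known here, so the size of this one cannot be read from the data shown. The expectation is that the step of a 3.3-fold higher number from compound 3 to compound 4 (0.52 log units; beyond the scatter) is a weakening beyond the scatter. Compound 4 is therefore estimated at 9000 nM, within a range from 2500 nM to 30000 nM.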

Compound 4, half-maximal inhibitory concentration: > 4000 nM
Compound 4: a limit, no number; the forecaster's own chance of this, stated with the estimate: 65%; the middle value does not contradict the limit.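

Among the compounds shown here, this is the first step that can be read at this position: hydroxy in place of butyl gives an at least 1.4-fold higher number from compound 3 to compound 4 (0.17 log units; that floor lies within the scatter). Compound 4 gives > 4000 nM, which is a limit of this assay and not a number. The change therefore brings no gain in inhibition, but whether it truly weakens inhibition, and by how much, cannot be told because the value is a limit: the limit of > 4000 nM in this assay, at which 2 of the 4 values shown sit.

The compounds shown leave open how an amine or a methoxy group would compare with butyl on this aromatic carbon. On these data alone, a longer chain such as hexyl also remains open.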